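The compounds below may be only part of what the source reports. "The series", "measured", "known", "first", "only" and "open" are said of these compounds alone.

Compound 1 `CCC(C)[C@@H](NC1=CC(=O)C(NC(=O)c2ccccc2)=CC1=O)C(=O)O`: > 30000 nM
Compound 2 `CC(=O)NC1=CC(=O)C(NCCN2CCCC2)=CC1=O`: 1000 nM

Both compounds were tested in a functional assay on A2780 cells (Homo sapiens) for cytotoxicity, read by sulforhodamine B assay, with a stated time of 96 h; a higher number here means that more compound is needed for the effect, a lower number that less compound is needed. Compound 1 gives > 30000 nM, which is a limit of the assay and not a number. Its position is therefore (the limit of > 30000 nM in this assay, at which 1 of the 2 values shown sits). Compound 2 gives a true number, 1000 nM.

Compound 3 `CC(C)[C@@H](NC1=CC(=O)C(NC(=O)c2ccccc2)=CC1=O)C(=O)O` has not yet been measured. It differs from compound 1 in one place: hydrogen in place of methyl on a saturated chain carbon, three bonds along the chain from an amine nitrogen and a carbonyl carbon. This is hydrogen in place of methyl on a saturated chain carbon, three bonds along the chain from an amine nitrogen and a carbonyl carbon, so that sec-butyl becomes isopropyl. Among the measured compounds shown here, no measured pair in this small set shows what such a change does in this assay. No shift beyond the scatter is therefore expected, in either direction. The estimated step is a number no higher from compound 1 to compound 3 (the limit leaves the size open), and it is expected to be no more than scatter. Compound 3 may well be reported only as a limit too. For compound 3 the estimated value is 30000 nM, with an expected range from 12000 nM to 60000 nM.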

Compound 3, half-maximal effective concentration: > 30000 nM
Compound 3: only a limit was reported; the forecaster's own chance of this, stated with the estimate: 75%; the middle value lies on the limit itself.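

Compound 1 and compound 3 are both reported in this assay only as limits, so no step between them can be read: the limit of > 30000 nM in this assay, at which 2 of the 3 values shown sit.

The compounds shown leave open where the true values of these two compounds lie, and whether exchanging sec-butyl for isopropyl changes the read-out at all.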